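Swapping a fluorophenyl for a pyridyl in coumarin amides

A few compounds are considered here, and "the series" means these few. Any claim that something is new, unique, unknown or untested is made for them only; others in the source may bear on it.

Of the compounds shown here, two that share one core have been tested in an assay (strain Wistar) for inhibition of Amine oxidase [flavin-containing] A (Rattus norvegicus); a lower number here means a stronger inhibitor, a higher number a weaker inhibitor. Compound 1 `NC(=O)Cc1cc(=O)oc2cc(OCc3cccc(Cl)c3)ccc12` gives 26000 nM, and compound 2 `NC(=O)Cc1cc(=O)oc2cc(OCc3cccc(F)c3)ccc12` gives 70000 nM. Going by the values given here, the one step between them, a 2.7-fold higher number from compound 1 to compound 2 (0.43 log units; beyond the scatter), is a fluoro in place of chloro on an aromatic carbon, and it leaves compound 2 with the highest number of the two, the nearer and only neighbour being compound 1.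

Compound 3 `NC(=O)Cc1cc(=O)oc2cc(OCc3cccnc3)ccc12` has not yet been measured in this assay. It differs from compound 2 by pyridin-3-yl in place of 3-fluorophenyl on a saturated chain carbon bound to an oxygen on an aromatic ring: a 3-fluorophenyl ring, with no hydrogen-bond acceptor, gives way to a pyridin-3-yl ring that carries one. Among the compounds with values here, no measured step touches this kind of change; the only step in hand, from compound 1 to compound 2, exchanged one halogen for another on the same ring and moved the number modestly upward. With nothing closer to lean on, the step is expected to be small, a 1.1-fold higher number from compound 2 to compound 3 (0.06 log units; within the scatter), and in this assay compound 3 is estimated at 80000 nM, with a plausible span from 25000 nM to 250000 nM.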

Compound 3, half-maximal inhibitory concentration: 21000 nM
Compound 3: the middle estimate sits 3.8-fold (0.58 log units) above what was measured; the whole stated range lies above it.
By their numbers in this assay, from the lowest: compounds 3 and 1 (each within the scatter of the next); then compound 2.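

In this assay, the ring on a saturated chain carbon bound to an oxygen on an aromatic ring need not be a halogen-bearing phenyl, since a pyridin-3-yl ring, which carries a hydrogen-bond acceptor, is tolerated here. Against 3-fluorophenyl the exchange gives a clear gain (a 3.3-fold lower number from compound 2 to compound 3 (0.52 log units; beyond the scatter)), whereas against 3-chlorophenyl it changes nothing that can be told from scatter (a 1.2-fold lower number from compound 1 to compound 3 (0.09 log units; within the scatter)), so the same ring exchange reads differently depending on which halogen it is compared with. No measurement is at hand that explains why the pyridin-3-yl ring matches the 3-chlorophenyl ring and not the 3-fluorophenyl ring.

From the compounds shown here alone, what remains open is whether the ring nitrogen matters in itself or whether the fluorine is simply the poorer partner at this place, a question that a plain phenyl ring would help to settle. Going by these compounds, it is also open whether the placing of the nitrogen counts, which pyridin-2-yl and pyridin-4-yl rings would test, and whether a methoxy group or a nitrile on the phenyl ring would fall with the chloro or with the fluoro compound.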